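Fluoro-methyl substitution on the distal phenyl of compound 1

This account rests on a few compounds, and the source may have more. Where it says the series, first, only, none or still open, it means among the compounds named here.

Working notes on a set of indole diacid antagonists measured in a functional assay on HEK293 cells for antagonist activity at cysteinyl leukotriene receptor 2 (Homo sapiens), read by fluorescence and calcium flux, with stated times of 30 min and 1 h; a higher number here means a weaker inhibitor, a lower number a stronger inhibitor. Compound 1 `Cc1c(CCCC(=O)O)c2cccc(/C=C/c3ccc(OCCCCc4ccccc4)cc3)c2n1CC(=O)O` gives 4.7 nM in this assay, the lowest of the three numbers recorded. Compound 3 `Cc1c(F)cccc1CCCCOc1ccc(C#Cc2cccc3c(CCCC(=O)O)c(C)n(CCCC(=O)O)c23)cc1` gives 8.8 nM; its number stands close to that of compound 1, within the usual scatter of such measurements, so no order between the two can be claimed. Compound 2 `Cc1c(Cl)cccc1CCCCOc1ccc(C#Cc2cccc3c(CCCC(=O)O)c(C)n(CCCCC(=O)O)c23)cc1` gives 30 nM, a higher number than compound 1 and beyond the scatter.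

Compound 4 `Cc1c(F)cccc1CCCCOc1ccc(/C=C/c2cccc3c(CCCC(=O)O)c(C)n(CC(=O)O)c23)cc1` has not yet been measured in this assay. It differs from compound 1 in one place: 3-fluoro-2-methylphenyl in place of phenyl on a saturated chain carbon, four bonds along the chain from an oxygen on an aromatic ring. For the measured compounds named here, no measured pair in the set isolates this change, so its size cannot be read from a recorded step. What is known is that compound 3, which also carries the 3-fluoro-2-methylphenyl group, sits within the scatter of compound 1 in this assay.

On that basis the step of a 1.2-fold higher number from compound 1 to compound 4 (0.07 log units; within the scatter) is expected to stay within the scatter, with no direction that can be asserted. Compound 4 is therefore estimated at 5.5 nM in this assay, with a likely range from 2 nM to 14 nM.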

Compound 4, half-maximal inhibitory concentration: 7.2 nM
Estimate against measurement, compound 4: 1.3-fold (0.12 log units) below; measured number inside the range.
By their numbers in this assay, from the lowest: compounds 1, 4 and 3 (each within the scatter of the next); then compound 2.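

Replacing phenyl with 3-fluoro-2-methylphenyl on a saturated chain carbon, four bonds along the chain from an oxygen on an aromatic ring, now has a directly measured step in this assay: a 1.5-fold higher number from compound 1 to compound 4 (0.19 log units; within the scatter), and the pair shares the rest of the structure of compound 1. Compound 3 carries the same group but differs from compound 1 in other places as well, so the steps among compounds 1, 2 and 3, and from compound 4 to compounds 2 and 3, cannot be read; this pair alone shows that, on the core of compound 1, this position takes the fluorine and methyl together without a change beyond the scatter. No supporting data bear on this result.

With the fluorine and methyl entering together, their separate contributions remain unresolved, and a group carrying only one of them would be needed to separate them. Also open, from the compounds shown here alone, is whether this position would tolerate a more different terminal group, such as cyclohexyl, pyridyl or a terminal carboxylic acid, or a shorter or longer chain leading to the ring.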